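Inverting the chain stereocentre of compound 2

The source may report more compounds than this note shows. Statements on the series, on what has been measured and on what is new or still open speak of the compounds shown alone.

Compound 2 `C[C@@H](Nc1c(C(N)=O)cnc2ccc(-c3cccnc3)cc12)C1CCOCC1` gives 14 uL/min in an ADME assay on cells (Hepatocyte, Homo sapiens) for metabolic stability, with a stated time of 90 min (a lower number here means slower removal, a higher number faster removal of the compound), and compound 1 `NC(=O)c1cnc2ccc(-c3cccnc3)cc2c1SC1CCCC1` gives 18 uL/min; the two numbers lie within the usual scatter of each other, as the step of a 1.3-fold lower number from compound 1 to compound 2 (0.11 log units; within the scatter) shows. Compound 3 `C[C@H](Nc1c(C(N)=O)cnc2ccc(-c3cccnc3)cc12)C1CCOCC1` differs from compound 2 as follows: the two compounds have the same atoms and bonds and differ only in configuration as drawn: 1 of 1 stereo elements differ; a stereocentre at a saturated chain carbon is drawn R in compound 2 and S in compound 3. Among the measured compounds shown here, the one measured step swaps a whole substituent, not a configuration, so no measured step bears directly on this change. No step beyond the scatter is therefore expected in this assay. Compound 3 is expected to give 14 uL/min, with a range from 7 uL/min to 28 uL/min. The expected step of no change at the digits printed from compound 2 to compound 3 (within the scatter) stays within the scatter.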

Compound 3, intrinsic clearance in a liver preparation (reported as CLH), per the amount of preparation that the assay uses: 14 uL/min
Estimate against measurement, compound 3: no gap at the digits printed, and the stated range covers the measured number.
By their numbers in this assay, from the lowest: compounds 2, 3 and 1 (each within the scatter of the next).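

Among the compounds shown here, this is the first reading on configuration at this chain carbon in this assay, and inverting it gives no change at the digits printed from compound 2 to compound 3 (within the scatter). The S form compares with the cyclopentylsulfanyl compound as the R form did, with a 1.3-fold lower number from compound 1 to compound 3 (0.11 log units; within the scatter), so neither drawn configuration separates from that compound. The comparison isolates the stereocentre alone: the fact that compounds 2 and 3 differ only in the configuration as drawn

From the compounds shown here alone, whether configuration stays without effect when a longer chain or an amine takes the place of the oxan-4-yl group remains open. So does the reading in any other assay.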